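A few compounds are considered here, and "the series" means these few. Any claim that something is new, unique, unknown or untested is made for them only; others in the source may bear on it.

Of the compounds shown here, two have been tested so far in a functional assay on the whole organism (strain Wistar) for inhibition, with Rattus norvegicus as the target, read by paw edema, with a stated time of 4 h, at a dose of 100 mg/kg; on this read-out higher numbers stand for more inhibition at the one dose given (going by the name of the read-out) and lower numbers for less inhibition. Compound 1, `COc1cc2c(cc1OC)C(CC(=O)O)CC2`, gives 23.9%. Compound 2, `COc1cc2c(cc1OC)C(CC(=O)Nc1ccccc1C)CC2`, gives 25%. The step of a number 1.1 percentage points higher from compound 1 to compound 2 (within the scatter), in which (2-methylphenyl)amino takes the place of hydroxy on the carbonyl carbon, lies within the scatter, so the two values cannot be told apart. Compound 2 stands highest of the two numbers, but only by a margin within the scatter, so its inhibition in this assay cannot be called higher than that of compound 1; the two numbers are level.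

Compound 3, `COc1cc2c(cc1OC)C(CC(=O)Nc1ccc(C)cc1)CC2`, is built from compound 2 by the change (4-methylphenyl in place of 2-methylphenyl on an amide-type nitrogen). The two compounds have the same atoms, joined differently. Among the measured compounds shown here, no measured step exchanges one methylphenyl group for another, so nothing measured bears directly on this change. For the measured compounds named here, the only known step, from hydroxy to an amide carrying an aromatic ring, did not shift the result beyond the scatter. The expected step from compound 2 to compound 3 in this assay is therefore no change at the digits printed from compound 2 to compound 3 (within the scatter), that is, none beyond the scatter. Compound 3 is expected to give 25% in this assay, with a range from 10% to 40%.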

Compound 3, a percentage reported as inhibition, in the whole organism at one dose (the size of the read-out at that dose, not a potency): 32.8%
Compound 3: the middle estimate sits 7.8 percentage points below what was measured; the range from low to high includes it.
By their numbers in this assay, from the lowest: compounds 1, 2 and 3 (each within the scatter of the next).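

Among the compounds shown here, this is the first measured exchange of one methylphenyl group for another on the amide-type nitrogen, and in this assay it gives a number 7.8 percentage points higher from compound 2 to compound 3 (within the scatter), so the 2-methylphenyl and 4-methylphenyl amides cannot be told apart at this dose. Putting (4-methylphenyl)amino in place of hydroxy on the carbonyl carbon gives a number 8.9 percentage points higher from compound 1 to compound 3 (within the scatter), so this amide, like the (2-methylphenyl)amino amide before it, cannot be separated from the carboxylic acid compound 1, and all three compounds remain level within the usual scatter of this measurement. No measurement available here offers an explanation for these numbers.

The compounds shown leave open what a plain phenyl, a 4-chlorophenyl or a 4-methoxyphenyl group would give on the same nitrogen, and so whether any group at this position can produce a step larger than the scatter. They also leave open how the result would look with an amine in place of the amide, or with a longer chain carrying the carbonyl on the shared core.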